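The source may report more compounds than this note shows. Statements on the series, on what has been measured and on what is new or still open speak of the compounds shown alone.

Within an ADME assay on HepG2 cells (Homo sapiens) for cytotoxicity, read by luminescence, CellTiter-Glo and ATP content, with a stated time of 72 h (on this read-out higher numbers stand for an effect only at larger amounts of compound and lower numbers for an effect already at smaller amounts), two compounds have been measured so far. Compound 1 `COc1ccc(Oc2ccc3c(NCCCNCc4cc(F)ccc4OC)ccnc3c2)cc1` gives 7000 nM. Compound 2 `COc1ccc(F)cc1CNCCCNc1ccnc2cc(CCC(C)C)ccc12` gives 890 nM, the lowest of the two numbers; the step of a 7.9-fold lower number from compound 1 to compound 2 (0.90 log units; beyond the scatter) separates them, and it was brought about by isopentyl in place of 4-methoxyphenoxy on an aromatic carbon.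

Compound 3 `COc1ccc(F)cc1CNCCCNc1ccnc2cc(CCc3ccccc3)ccc12` has not yet been measured. It differs from compound 2 by phenyl in place of isopropyl on a saturated chain carbon, two bonds along the chain from an aromatic carbon. For the measured compounds named here, the only measured step that bears on this site is the one from compound 1 to compound 2, which reached a 7.9-fold lower number from compound 1 to compound 2 (0.90 log units; beyond the scatter) when an aromatic ring was exchanged for a branched saturated chain at that aromatic carbon. Compound 3 brings an aromatic ring back, though as phenyl on a saturated chain carbon rather than as 4-methoxyphenoxy, so compound 3 is expected to land between the two measured compounds, with a shift of a 1.8-fold higher number from compound 2 to compound 3 (0.25 log units; within the scatter) that may or may not exceed the scatter. The estimate for compound 3 in this assay is therefore 1600 nM, with a range from 600 nM to 4500 nM.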

Compound 3, half-maximal effective concentration: 4240 nM
Estimate against measurement, compound 3: 2.7-fold (0.42 log units) below; the range from low to high includes it.
By their numbers in this assay, from the lowest: compound 2; then compounds 3 and 1 (each within the scatter of the next).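

In this assay the end of this chain now proves to matter: with the rest of compound 2 kept, phenyl in place of isopropyl gives a 4.8-fold higher number from compound 2 to compound 3 (0.68 log units; beyond the scatter) and takes back much of what isopentyl had gained over 4-methoxyphenoxy. The low number of compound 2 is therefore not a feature of every saturated link on this aromatic carbon, since phenethyl, which also starts with saturated carbons, gives a 1.7-fold lower number from compound 1 to compound 3 (0.22 log units; within the scatter) and so cannot be told apart from 4-methoxyphenoxy in this read-out, even though the two groups differ in more than one feature. Nothing measured here explains why the phenyl end gives the higher number.

The compounds shown leave open whether the higher number follows from the aromatic ring or simply from a larger ring-bearing end, and a cyclohexyl group at the same chain end would separate these two readings. They also leave open how a shorter link such as benzyl, or an amine or a carboxylic acid at the end of the chain, would behave in this assay.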